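The source may report more compounds than this note shows. Statements on the series, on what has been measured and on what is new or still open speak of the compounds shown alone.

Of the compounds shown here, three that share one core have been tested in a functional assay on DU-145 cells (Homo sapiens) for inhibition, read by trypan blue exclusion, with a stated time of 96 h; a higher number here means a weaker inhibitor of growth, a lower number a stronger inhibitor of growth. Compound 1 `Cc1ccc(CS(=O)(=O)/C(=C/c2ccc(Br)cc2)C(=O)c2ccc(Cl)cc2)cc1` gives 25000 nM in this assay. Compound 3 `CSc1ccc(/C=C(/SCc2ccc(C)cc2)C(=O)c2ccc(Cl)cc2)cc1` gives 25000 nM, the same number at the digits reported, so the two cannot be told apart. Compound 2 `COc1ccc(/C=C(/Sc2ccc(C)cc2)C(=O)c2ccc(Br)cc2)cc1` gives 50000 nM, and its gap from compound 1 also lies within the usual scatter of repeated measurements, so all three read as weak inhibitors of growth of about equal strength, with no ordering among them that the scatter would support.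

Compound 4 `Cc1ccc(CS(=O)(=O)/C(=C/c2c(O)cc(O)cc2O)C(=O)c2ccc(Cl)cc2)cc1` has not yet been measured. It differs from compound 1 in one place: 2,4,6-trihydroxyphenyl in place of 4-bromophenyl on a double-bonded chain carbon bound to a double-bonded chain carbon. For the measured compounds named here, no pair among the measured compounds changes only this part, so there is no measured step to lean on, and none of the three measured numbers speaks to a trihydroxyphenyl group. Only a small step is expected, with no direction beyond the scatter claimed, namely a 1.2-fold higher number from compound 1 to compound 4 (0.08 log units; within the scatter). Compound 4 is estimated at 30000 nM, within a range from 8000 nM to 100000 nM.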

Compound 4, concentration for 50% growth inhibition: > 100000 nM
Compound 4 was reported as a limit (the forecaster's own chance of this, stated with the estimate: 15%); at least 3.3-fold (0.52 log units) between middle value and limit.
By their numbers in this assay, from the lowest: compounds 1, 3 and 2 (each within the scatter of the next). At a limit, above all of these: compound 4.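

For compound 4, > 100000 nM in this assay is a limit of the assay and not a number. The earlier compounds shown here all lay within the scatter of one another, whereas 2,4,6-trihydroxyphenyl in place of 4-bromophenyl on a double-bonded chain carbon bound to a double-bonded chain carbon gives an at least 4.0-fold higher number from compound 1 to compound 4 (0.60 log units; beyond the scatter), so growth inhibition at this position does depend on the group carried there. This step marks only the smallest gap the data allow, and its true size stays unknown: the limit of > 100000 nM in this assay, at which 1 of the 4 values shown sits.

One swap cannot tell whether the loss follows from the hydroxyl groups arriving or from the bromine leaving. It also leaves open how this position would respond to an amine or a carboxylic acid on this ring, and whether any group here could give a lower number than compound 1.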